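The source may hold more compounds than are shown below. What is called first, only, known or untested is meant among the compounds shown, and "the series" means these compounds.

In an ADME assay on microsomes from liver (Homo sapiens) for pharmacokinetics, read by LC-MS, with a stated time of 60 min, tested at 1 uM (on this read-out lower numbers stand for slow clearance and higher numbers for fast clearance), compound 1 `C[C@@H]1COC[C@@H](C)N1S(=O)(=O)c1ccc(NC(=O)NCc2cccnc2)cc1` gives 17 mL/min/kg and compound 2 `CC1CNCCN(S(=O)(=O)c2ccc(NC(=O)NCc3cccnc3)cc2)C1` gives 8 mL/min/kg, the lower of the two numbers. Compound 3 `CC1CCN(S(=O)(=O)c2ccc(NC(=O)NCc3cccnc3)cc2)CCN1` differs from compound 2 by a group of 8 heavy atoms (6 carbon, 2 nitrogen; one seven-membered non-aromatic ring with 2 hetero atoms) in place of a group of 8 heavy atoms (6 carbon, 2 nitrogen; one seven-membered non-aromatic ring with 2 hetero atoms), on a sulfonyl sulfur; the two have the same atoms, joined differently. Within the data shown here, only one measured step bears on this, a 2.1-fold lower number from compound 1 to compound 2 (0.33 log units; beyond the scatter), a modest step that replaced a six-membered ring with a seven-membered one. Among the measured compounds shown here, no measured step rearranges the seven-membered ring itself. The expected step is a 1.1-fold higher number from compound 2 to compound 3 (0.05 log units; within the scatter), within the scatter and with no direction foreseen. Compound 3 is estimated at 9 mL/min/kg, with an expected range from 5 mL/min/kg to 16 mL/min/kg.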

Compound 3, clearance: 5 mL/min/kg
Estimate against measurement, compound 3: 1.8-fold (0.26 log units) above; measured number inside the range.
By their numbers in this assay, from the lowest: compounds 3 and 2 (each within the scatter of the next); then compound 1.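

Rejoining the same atoms within the seven-membered ring on the sulfonyl sulfur gives a 1.6-fold lower number from compound 2 to compound 3 (0.20 log units; within the scatter), so in this assay this rearrangement does not set the two isomers apart. Against the six-membered ring with 2 hetero atoms, the rearranged ring gives a 3.4-fold lower number from compound 1 to compound 3 (0.53 log units; beyond the scatter), so the earlier step beyond the scatter is not tied to one arrangement of the seven-membered ring. No available evidence accounts for either step. The compounds shown leave open how a piperidine or an open-chain amine on the sulfonyl sulfur would read.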